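The compounds below may be only part of what the source reports. "The series", "measured", "known", "first", "only" and "open" are said of these compounds alone.

Compound 1 `CC#C[C@@H](CC(=O)O)c1ccc(OC[C@H]2COc3ccc(Cl)cc3O2)cc1`: 50 nM
Compound 2 `CC#C[C@@H](CC(=O)O)c1ccc(OC[C@H]2COc3ccc(C#N)cc3O2)cc1`: 2100 nM

Both values come from a functional assay on HEK293 cells for agonist activity at Free fatty acid receptor 1 (Homo sapiens), read by fluorescence and calcium flux, with a stated time of 10 min; a lower number here means that less compound is needed, a higher number that more compound is needed for the effect. Among the two measured compounds, compound 2 holds the highest number; its only neighbour is compound 1, and the single measured step, a 42-fold higher number from compound 1 to compound 2 (1.62 log units; beyond the scatter), was large and beyond the scatter.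

Compound 3 `CC#C[C@@H](CC(=O)O)c1ccc(OC[C@H]2COc3ccc(C(C)=O)cc3O2)cc1` has not been measured yet. It differs from compound 2 in one place: acetyl in place of cyano on an aromatic carbon. For the measured compounds named here, the one measured step touches the same position, but it exchanged a different pair of groups, so it shows only that this position can move the number strongly; no measured pair compares acetyl with cyano directly. With nothing firmer to go on, compound 3 is expected to land near compound 2, the estimate in this assay being 1500 nM, within a wide range from 300 nM to 7000 nM. The expected step is therefore a 1.4-fold lower number from compound 2 to compound 3 (0.15 log units; within the scatter).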

Compound 3, half-maximal effective concentration: > 30000 nM
Compound 3 ended at the assay's limit; the forecaster's own chance of this, stated with the estimate: 5%; middle value at least 20-fold (1.30 log units) away from the limit.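

Compound 3 gives no exact number, only a limit: the limit of > 30000 nM in this assay, at which 1 of the 3 values shown sits. Even so, the steps can be read as minimum sizes: acetyl in place of cyano brought an at least 14-fold higher number from compound 2 to compound 3 (1.15 log units; beyond the scatter), and acetyl in place of chloro brought an at least 600-fold higher number from compound 1 to compound 3 (2.77 log units; beyond the scatter). The earlier pair showed only that this position can move the number strongly, whereas this result shows that cyano and acetyl, which each count one hydrogen-bond acceptor, no donor and no net charge, still end far apart, so matching those counts does not keep the numbers together here.

The compounds shown compare only chloro, cyano and acetyl at this position, leaving open how a fluoro, a methyl or an amine there would compare with compound 1. They also do not tell why the number moves so far.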